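Swapping 4-Chlorophenyl for 2-Chlorophenyl in Two Cores

A few compounds are considered here, and "the series" means these few. Any claim that something is new, unique, unknown or untested is made for them only; others in the source may bear on it.

Compound 1 `CN(C)CCCNc1nc(-c2ccc(NC(=O)Nc3ccc(Cl)cc3)cc2)nc2c(Cl)c(Cl)sc12` and compound 2 `CN(C)CCCNc1nc(-c2ccc(NC(=O)Nc3ccccc3Cl)cc2)nc2c(Cl)c(Cl)sc12` share one core; compound 3 `CCN(CC)CCCNc1nc(-c2ccc(NC(=O)Nc3ccc(Cl)cc3)cc2)nc2ccsc12` and compound 4 `CCN(CC)CCCNc1nc(-c2ccc(NC(=O)Nc3ccccc3Cl)cc2)nc2ccsc12` share another, and the difference between the two cores is not broken down here. In a functional assay on MDA-MB-231 cells (Homo sapiens) for cytotoxicity, read by MTT assay, with a stated time of 72 h (on this read-out lower numbers stand for stronger inhibition and higher numbers for weaker inhibition), compound 1 gives 1160 nM and compound 2 gives 1560 nM; the change 2-chlorophenyl in place of 4-chlorophenyl on an amide-type nitrogen made a 1.3-fold higher number from compound 1 to compound 2 (0.13 log units; within the scatter). In this assay compound 3 gives 230 nM, the lowest of the three numbers. Compound 4 carries the same change, (2-chlorophenyl in place of 4-chlorophenyl on an amide-type nitrogen), on the core of compound 3. Because a 1.3-fold higher number from compound 1 to compound 2 (0.13 log units; within the scatter) was within the scatter, a similar step is expected here, a 1.3-fold higher number from compound 3 to compound 4 (0.12 log units; within the scatter). Compound 4 is therefore estimated at 300 nM, with a range of 120 nM to 750 nM.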

Compound 4, half-maximal inhibitory concentration: 500 nM
Beside the measured number, compound 4's estimate is 1.7-fold (0.22 log units) below it; measured number inside the range.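

In this assay, placing 2-chlorophenyl in place of 4-chlorophenyl on an amide-type nitrogen gave a 2.2-fold higher number from compound 3 to compound 4 (0.34 log units; beyond the scatter), a modest step beyond the scatter, whereas the same change on the core of compound 1 stayed within it. Even so, the two steps cannot be told apart: the same change on two cores in this assay, a 1.3-fold higher number (0.13 log units; within the scatter) from compound 1 to compound 2 and a 2.2-fold higher number (0.34 log units; beyond the scatter) from compound 3 to compound 4, 1.6-fold (0.21 log units) apart, within the scatter of two such steps. The step measured on one core is therefore compatible with the step on the other, but two pairs show only that and do not establish that it would hold on any further core.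

On these data alone, it remains open whether the step would look the same with a fluorine or a methoxy group in place of the chlorine on the phenyl ring. Also open, as far as these compounds go, is whether it would hold on a core carrying a morpholine in place of the dimethylamino or diethylamino group.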